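The source may report more compounds than this note shows. Statements on the series, on what has been measured and on what is new or still open speak of the compounds shown alone.

Compound 1 `C=CC(C)(C/C=C(\C)CCC=C(C)C)c1ccc(O)c(O)c1` carries two free hydroxyl groups on its aromatic ring, and in a functional assay on HL-60 cells (Homo sapiens) for cytotoxicity, read by MTT assay, with a stated time of 72 h (on this read-out lower numbers stand for stronger inhibition and higher numbers for weaker inhibition), compound 1 gives 6.17 ug/mL. Compound 2 `C=CC(C)(C/C=C(\C)CCC=C(C)C)c1ccc(OCc2ccccc2)c(OCc2ccccc2)c1` has both of those oxygens capped with benzyl groups, and in this assay compound 2 is reported as "not active" (no number reported), with no number attached. Compound 2 therefore stands without a measured concentration, and it is not alone in this: compound 3 `C=CC(C)(C/C=C(\C)CCC=C(C)C)c1ccc(OCc2ccccc2)c(O)c1`, which keeps one free hydroxyl and one benzyl, is likewise reported in this assay as "not active" (no number reported). Among the three measured compounds only compound 1 has a numerical value.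

Compound 4 `C=CC(C)(C/C=C(\C)CCC=C(C)C)c1ccc(O)c(OCc2ccccc2)c1` is the remaining member of the set and has not yet been tested. It differs from compound 2 as follows: hydrogen in place of benzyl on an oxygen on an aromatic ring. Compound 4 thus ends up with one hydroxyl and one benzyl ether, as compound 3 does, though on the other oxygen. Going by the values given here, no step between measured compounds is available to set the size of this change; compound 3 shows that one free hydroxyl did not restore a measurable value, while compound 1 shows that two did. In this assay compound 4 is expected to give roughly 25 ug/mL, within a range of 8 ug/mL to 80 ug/mL, with a real chance that it is again reported without a number.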

Compound 4, half-maximal inhibitory concentration: 12.4 ug/mL
For compound 4 the middle estimate is 2.0-fold (0.30 log units) above the measured one, within the range that was stated.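

In this assay, putting a benzyl group on this oxygen of compound 1 gives a 2.0-fold higher number from compound 1 to compound 4 (0.30 log units; within the scatter), so a free hydroxyl at this position is not needed for a measurable value, and an aromatic benzyl ether can be carried here. The earlier compounds shown here did not show this: compound 2 and compound 3 both came without a number, which left open the reading that any benzyl ether on the shared core ends the activity, whereas the comparison of compound 1 with compound 3 and of compound 2 with compound 4 now ties the loss to benzyl on the other oxygen, and the steps involving compound 2 and compound 3 cannot be read as sizes. Nothing available explains why the two oxygens behave differently.

On these data alone, what remains open is whether this oxygen accepts other groups as well, such as a methyl ether, an acetyl ester or a chain carrying an amine or a carboxylic acid. As far as these compounds go, it is equally open whether a small group such as methyl on the other oxygen would be reported with a number, or whether a shorter chain on the core would change these results.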